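This account rests on a few compounds, and the source may have more. Where it says the series, first, only, none or still open, it means among the compounds named here.

The measured compounds are:
compound 1 `CC1=CSC2=NC(/C=C/c3ccccc3Cl)=C(C(=O)/C=C/c3ccccc3Cl)C(c3ccccc3)N12`, which in an ADME assay on Vero cells (Chlorocebus sabaeus) for cytotoxicity, read by fluorescence and resazurin assay, with a stated time of 72 h (a higher number here means that more compound is tolerated, a lower number that less compound is tolerated), gives 206 ug/mL;
compound 2 `CC1=CSC2=NC(/C=C/c3ccc(OCc4ccccc4)cc3)=C(C(=O)/C=C/c3ccc(OCc4ccccc4)cc3)C(c3ccccc3)N12`, for which this assay gives only a limit, > 500 ug/mL;
compound 3 `CC1=CSC2=NC(/C=C/c3ccccc3Cl)=C(C(=O)/C=C/c3ccccc3Cl)C(c3ccc(Cl)cc3)N12`, which in this assay gives 430 ug/mL.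

Compound 3 differs from compound 1 in one place, (chloro in place of hydrogen on an aromatic carbon), and that change produced a 2.1-fold higher number from compound 1 to compound 3 (0.32 log units; beyond the scatter). Compound 2 and compound 1 differ in more than one place, and the difference between the two cores is not broken down here. For compound 2 the measurement stops at a limit of the assay, (the limit of > 500 ug/mL in this assay, at which 1 of the 3 values shown sits), so no number stands for it.

Compound 4 `CC1=CSC2=NC(/C=C/c3ccc(OCc4ccccc4)cc3)=C(C(=O)/C=C/c3ccc(OCc4ccccc4)cc3)C(c3ccc(Cl)cc3)N12` has not yet been measured. It differs from compound 2 by chloro in place of hydrogen on an aromatic carbon, the same change that a 2.1-fold higher number from compound 1 to compound 3 (0.32 log units; beyond the scatter) shows. Because a 2.1-fold higher number from compound 1 to compound 3 (0.32 log units; beyond the scatter) went upward, and because compound 2 already sits at a limit, > 500 ug/mL, compound 4 is not expected to come out any lower. For compound 4 in this assay the step is expected to be a step that the limit leaves unreadable from compound 2 to compound 4 and the value is estimated at 900 ug/mL, between 450 ug/mL and 2500 ug/mL. It is expected that this assay will most likely report only a limit for compound 4.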

Compound 4, half-maximal cytotoxic concentration: 500 ug/mL
Beside the measured number, compound 4's estimate is 1.8-fold (0.26 log units) above it; the range from low to high includes it.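

Set side by side, the change from phenyl to 4-chlorophenyl gives one step that can be read and one that cannot: the same change on two cores in this assay, a 2.1-fold higher number (0.32 log units; beyond the scatter) from compound 1 to compound 3 and a number no higher (the limit leaves the size open) from compound 2 to compound 4; the limit leaves it open whether they differ. In this assay compound 2 stands at a limit, > 500 ug/mL, which is a limit of the assay and not a number: the limit of > 500 ug/mL in this assay, at which 1 of the 4 values shown sits. On this core the change from phenyl to 4-chlorophenyl gives a number no higher from compound 2 to compound 4 (the limit leaves the size open). Compound 4 gives 500 ug/mL, yet with no number for compound 2 this neither confirms nor contradicts on the second core the rise seen on the first, so the series shows that the change can be placed on both cores but gives no measured size for it on the second.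

The compounds shown leave open how a group other than chloro, such as a methoxy group or an amine, would act in the same place on the phenyl ring. They also leave open whether the chloro change would read the same on a core carrying a carboxylic acid, where the values might stay clear of the limit.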